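Working notes: hydroxy for methoxy, toward compound 4

The compounds below may be only part of what the source reports. "The series", "measured", "known", "first", "only" and "open" are said of these compounds alone.

Measured so far in a functional assay on SW-620 cells (Homo sapiens) for inhibition, read by sulforhodamine B assay, with a stated time of 48 h; a lower number here means that less compound is tolerated, a higher number that more compound is tolerated:
compound 1 `O=C(Nc1cccc(-n2cc(-c3ccncc3)c(-c3ccc(Cl)c(O)c3)n2)c1)Nc1cccc(C(F)(F)F)c1`: > 32500 nM
compound 2 `O=C(Nc1cccc(-n2cc(-c3ccncc3)c(-c3ccc(Cl)c(O)c3)n2)c1)Nc1ccc(Cl)c(Cl)c1`: > 32500 nM
compound 3 `COc1cc(-c2nn(-c3cccc(NC(=O)Nc4ccc(Cl)c(C(F)(F)F)c4)c3)cc2-c2ccncc2)ccc1Cl`: > 32500 nM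

Within the data shown here, every value so far is a limit of this assay rather than a number. For compound 1 the value given is a limit. For compound 2 the value given is likewise a limit. For compound 3 the value given is also a limit. Among the measured compounds shown here, the one step between measured compounds that differ in a single place, a step that the two limits leave unreadable from compound 1 to compound 2, is unreadable because the limit of > 32500 nM in this assay, at which 3 of the 3 values shown sit, holds at both of its ends.

Compound 4 `O=C(Nc1cccc(-n2cc(-c3ccncc3)c(-c3ccc(Cl)c(O)c3)n2)c1)Nc1ccc(Cl)c(C(F)(F)F)c1` differs from compound 3 by hydrogen in place of methyl on an oxygen on an aromatic ring. For the measured compounds named here, no measured step bears on this change. Compound 1 and compound 2 already carry the hydroxy group on the same ring as compound 4, and both sit at the limit. Compound 4 is therefore expected to sit at the limit as well, with a step that the limit leaves unreadable from compound 3 to compound 4 expected to show none beyond the scatter. The estimate for compound 4 is 40000 nM, within 15000 nM to 100000 nM.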

Compound 4, concentration lethal to 50% of the cells: > 32500 nM
Compound 4: a limit, no number; the forecaster's own chance of this, stated with the estimate: 80%; the middle value lies beyond the limit too.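

No new step can be read among compound 1, compound 2, compound 3 and compound 4, because all of them end at one limit: the limit of > 32500 nM in this assay, at which 4 of the 4 values shown sit.

The compounds shown leave open whether methoxy to hydroxy, or any other change among them, alters the result in this assay.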